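The compounds below may be only part of what the source reports. "The series", "measured", "known", "first", "only" and "open" are said of these compounds alone.

Two compounds share one core and differ only in the group attached to the amine nitrogen. Compound 1 `CCOC(=O)C1=C(Nc2ccccc2Br)S/C(=C\c2ccc[nH]2)C1=O` carries a 2-bromophenyl there and in a functional assay on JAR cells (Homo sapiens) for inhibition, read by MTT assay, with a stated time of 72 h, tested at 10 uM (a lower number here means less inhibition, a higher number more inhibition at the concentration tested (going by the name of the read-out)), compound 1 gives 62.7%. Compound 2 `CCOC(=O)C1=C(Nc2ccc(F)cc2)S/C(=C\c2ccc[nH]2)C1=O` carries a 4-fluorophenyl instead, and in this assay compound 2 gives 61.5%. The only step between them, a number 1.2 percentage points lower from compound 1 to compound 2 (within the scatter), stays within the scatter, so on the numbers shown compound 2 sits at the lower of two figures that cannot be told apart.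

Compound 3 `CCOC(=O)C1=C(Nc2ccc([N+](=O)[O-])cc2)S/C(=C\c2ccc[nH]2)C1=O` is not yet measured. It differs from compound 2 by nitro in place of fluoro on an aromatic carbon. Within the data shown here, the single step seen so far, a change of the group on the amine nitrogen, moved the read-out by an amount within the scatter, so for compound 3 the expected step is about a number 1.5 percentage points lower from compound 2 to compound 3 (within the scatter) in this assay, again one that stays within the scatter. Compound 3 is estimated at 60%, between 45% and 75%.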

Compound 3, a percentage reported as inhibition, at one concentration (the size of the read-out at that concentration, not a potency): 54.9%
Beside the measured number, compound 3's estimate is 5.1 percentage points above it; the measured number falls inside the stated range.
By their numbers in this assay, from the lowest: compounds 3, 2 and 1 (each within the scatter of the next).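

Going from fluoro to nitro on this aromatic carbon, para to a large group, brings in more heavy atoms and hydrogen-bond acceptors, yet in this assay it gives a number 6.6 percentage points lower from compound 2 to compound 3 (within the scatter) as its step. The wider swap, 4-nitrophenyl in place of 2-bromophenyl on the amine nitrogen, gives a number 7.8 percentage points lower from compound 1 to compound 3 (within the scatter) and so also leaves the figures within reach of one another, which means these three aromatic groups cannot be told apart in this read-out. No measurement shown here explains the numbers.

Open, from the compounds shown here alone, is whether an amine or a carboxylic acid on this same aromatic carbon would move the figure beyond the scatter. Also open, going by these compounds, is whether a longer chain in place of the ethyl group of the ester, elsewhere on the shared core, would matter more than these aromatic changes.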